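The compounds below may be only part of what the source reports. "The series", "measured", "known", "first", "only" and "open" are said of these compounds alone.

Measured compounds in an assay on Sf9 cells for inhibition of histone deacetylase 11 (Homo sapiens), read by mobility shift assay; a lower number here means a stronger inhibitor, a higher number a weaker inhibitor:
compound 1 `O=C(NO)c1ccc(N(Cc2ccc(C(F)(F)F)cc2)C(=O)CN(Cc2ccccc2C(F)(F)F)S(=O)(=O)c2ccc(F)c(F)c2)cc1` gives 396 nM
compound 2 `CC(C)(C)c1ccc(CN(C(=O)CN(Cc2c(F)c(F)c(F)c(F)c2F)S(=O)(=O)c2ccc(F)cc2)c2ccc(C(=O)NO)cc2)cc1` gives 636 nM
compound 3 `O=C(NO)c1ccc(N(Cc2ccc(C(F)(F)F)cc2)C(=O)CN(Cc2c(F)c(F)c(F)c(F)c2F)S(=O)(=O)c2ccc(F)cc2)cc1` gives 191 nM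

Compound 3 has the lowest number of the three; the values of compound 1 and compound 2 lie within the scatter of each other. The change from compound 3 to compound 2 is tert-butyl in place of trifluoromethyl on an aromatic carbon and produced a 3.3-fold higher number from compound 3 to compound 2 (0.52 log units; beyond the scatter).

Compound 4 `CC(C)(C)c1ccc(CN(C(=O)CN(Cc2ccccc2C(F)(F)F)S(=O)(=O)c2ccc(F)c(F)c2)c2ccc(C(=O)NO)cc2)cc1` is not yet measured. It differs from compound 1 by tert-butyl in place of trifluoromethyl on an aromatic carbon, the same change at the same place as between compound 3 and compound 2. How the core of compound 1 differs from the core of compound 3 is not broken down here.

For compound 4 a step of a 3.3-fold higher number from compound 1 to compound 4 (0.52 log units; beyond the scatter) is expected, because the same change gave a 3.3-fold higher number from compound 3 to compound 2 (0.52 log units; beyond the scatter). Compound 4 is therefore estimated at 1300 nM, with the expected range 500 nM to 3500 nM.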

Compound 4, half-maximal inhibitory concentration: 254 nM
Compound 4: the middle estimate sits 5.1-fold (0.71 log units) above what was measured, outside the stated range (below it).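

In this assay tert-butyl in place of trifluoromethyl on the core of compound 1 gives a 1.6-fold lower number from compound 1 to compound 4 (0.19 log units; within the scatter). The change therefore cannot be carried at a fixed size from the core of compound 3 to the core of compound 1: the same change on two cores in this assay, a 3.3-fold higher number (0.52 log units; beyond the scatter) from compound 3 to compound 2 and a 1.6-fold lower number (0.19 log units; within the scatter) from compound 1 to compound 4, 5.2-fold (0.72 log units) apart, beyond the scatter of two such steps. These two pairs show that the outcome of this change depends on the core, but they do not show which difference between the cores is responsible, and they set no rule for other cores.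

From the compounds shown here alone, it remains open how the change would read on a core carrying only one of those differences. Also open, going by these compounds, is whether a methoxy group or a nitrile on that same aromatic carbon would behave alike on both cores.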